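This account rests on a few compounds, and the source may have more. Where it says the series, first, only, none or still open, it means among the compounds named here.

Measured so far, all in an ADME assay on PC-3 cells (Homo sapiens) for cytotoxicity, read by WST assay, tested at 100 uM; a higher number here means more inhibition at the concentration tested (going by the name of the read-out), a lower number less inhibition:
Compound 1 `CSc1cccc(C(=O)N2CCCC(C(=O)Nc3ccc(Cl)cc3)C2)c1` gives 0%.
Compound 2 `COc1cccc(C(=O)N2CCCC(C(=O)Nc3ccc(Cl)cc3)C2)c1` gives 0%.
Compound 3 `COC(=O)c1cccc(C(=O)N2CCCC(C(=O)Nc3ccc(Cl)cc3)C2)c1` gives 0%.

Compound 3 stands level with the other two at the digits shown: the step of no change at the digits printed from compound 1 to compound 3 (within the scatter) and the step of no change at the digits printed from compound 2 to compound 3 (within the scatter) are both within the scatter, as is the step of no change at the digits printed from compound 1 to compound 2 (within the scatter) between the two compounds that do not carry the methoxycarbonyl group. Nothing among these three compounds moves this assay off its floor.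

Compound 4 `O=C(c1ccccc1)c1cccc(C(=O)N2CCCC(C(=O)Nc3ccc(Cl)cc3)C2)c1` takes the step from compound 3 in which (phenyl in place of methoxy on a carbonyl carbon). Among the compounds with values here, three measured steps bear on it, each a swap of a single substituent on the shared aromatic ring of the core, and each came out as no change within the scatter. The group that enters in compound 4 is larger than anything that has entered so far, but the measured steps give no sign that any substituent at this position, small or large, changes the read-out.

Compound 4 is therefore expected to show no step beyond the scatter in this assay, with no change at the digits printed from compound 3 to compound 4 (within the scatter), and its estimated value is 0%, in the range -5% to 15%.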

Compound 4, a percentage reported as inhibition, at one concentration (the size of the read-out at that concentration, not a potency): 0%
Compound 4: the middle estimate sits on the measured number at the digits printed; measured number inside the range.
By their numbers in this assay, from the lowest: compounds 1, 2, 3 and 4 (each within the scatter of the next).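

In this assay, phenyl in place of methoxy on a carbonyl carbon gives no change at the digits printed from compound 3 to compound 4 (within the scatter) and so brings a ring into this group, with six heavy atoms entering where two leave, without moving the read-out. Benzoyl in place of methoxy on an aromatic carbon gives no change at the digits printed from compound 2 to compound 4 (within the scatter) and benzoyl in place of methylsulfanyl on an aromatic carbon gives no change at the digits printed from compound 1 to compound 4 (within the scatter) as well, so the range of groups tested at this place now runs from methoxy to benzoyl and all four compounds stand level. With every compound sitting on the floor of this assay, the steps show that none of these swaps lifts the read-out, but they give no size of effect to compare, and no other measurement here bears on why the values stay there.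

Still open, going by these compounds, is whether an amine or a carboxylic acid at this place on the shared core, or a longer chain in place of the phenyl of compound 4, would lift the read-out off the floor. Also open, on these data alone, is whether a change elsewhere on the shared core, such as an amine in place of the chlorine, would do so where these four swaps did not.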